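The compounds below may be only part of what the source reports. "The series", "measured", "known", "first", "only" and "open" are said of these compounds alone.

Measured compounds in a functional assay on MCF7 cells (Homo sapiens) for inhibition, read by MTT assay, with a stated time of 24 h; a lower number here means a stronger inhibitor, a higher number a weaker inhibitor:
compound 1, `O=C(Cn1c(=O)c(/C=C\c2ccncc2)nc2ccccc21)Nc1ccc(Cl)c(Cl)c1`: 47600 nM
compound 2, `Cc1nc2ccccc2nc1OCC(=O)Nc1ccc(Cl)cc1`: > 100000 nM

Both compounds carry a chloro-substituted anilide attached through a short linker to a shared core, and both are weak inhibitors. In this assay compound 1 gives 47600 nM, a measurable though high concentration. For compound 2 the assay reports only a limit: in this assay compound 2 gives > 100000 nM. That value is the limit of > 100000 nM in this assay, at which 1 of the 2 values shown sits, so compound 2 stands at the edge of what the measurement can report, and all that can be said is that it lies at or beyond the weakest result the assay resolves.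

Compound 3, `O=C(COc1nc2ccccc2nc1/C=C\c1ccncc1)Nc1ccc(Cl)cc1`, is not yet measured. It differs from compound 2 in one place: 2-(pyridin-4-yl)ethenyl in place of methyl on an aromatic carbon. The same 2-(pyridin-4-yl)ethenyl group is present in compound 1, which did return a number. Going by the values given here, no measured pair covers this change, so the expectation rests on that comparison alone. The expected step is an at least 1.6-fold lower number from compound 2 to compound 3 (0.22 log units; that floor lies within the scatter), small and within the usual scatter. Compound 3 is estimated at 60000 nM, with a range from 25000 nM to 150000 nM.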

Compound 3, half-maximal inhibitory concentration: > 100000 nM
Compound 3 gave a limit, no number; the forecaster's own chance of this, stated with the estimate: 35%; middle value at least 1.6-fold (0.22 log units) away from the limit.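

In this assay compound 3, like compound 2, returns only a limit and not a number, so no step can be read between compound 2 and compound 3: the limit of > 100000 nM in this assay, at which 2 of the 3 values shown sit.

The compounds shown leave open whether 2-(pyridin-4-yl)ethenyl in place of methyl on an aromatic carbon changes inhibition at all, and how far past the limit either compound lies.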